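The source may hold more compounds than are shown below. What is called first, only, known or untested is meant among the compounds shown, and "the series" means these compounds.

In a physicochemical assay for solubility, read by LC-MS, in phosphate buffer, with a stated time of 24 h, at pH 6.8 (on this read-out lower numbers stand for lower solubility and higher numbers for higher solubility), compound 1 `CCC(=O)N[C@@H](C)c1ccc(NC(=O)N2CC(c3cccnc3)C2)cc1` gives 700000 nM while compound 2 `CCC(=O)N[C@@H](C)c1ccc(NC(=O)N2CC(c3ccc(N)nc3)C2)cc1` gives 760000 nM and compound 3 `C[C@H](NC(=O)C1CCOCC1)c1ccc(NC(=O)N2CC(c3cncc(N)c3)C2)cc1` gives 440000 nM so compound 3 stands within the usual scatter of both others. The change leading to compound 4 `CCC(=O)N[C@@H](C)c1ccc(NC(=O)N2CC(c3cncc(N)c3)C2)cc1` is ethyl in place of oxan-4-yl on a carbonyl carbon and gives it the propanoyl of compound 1 and compound 2. Within the data shown here, no measured pair tests this swap directly. Among the measured compounds shown here, the only measured step of a 1.1-fold higher number from compound 1 to compound 2 (0.04 log units; within the scatter) is amino in place of hydrogen on an aromatic carbon and lies within the scatter, so no step beyond the scatter is expected in this assay here. The estimated step of a 1.5-fold higher number from compound 3 to compound 4 (0.17 log units; within the scatter) therefore stays within the scatter. Compound 4 is expected at 650000 nM with 350000 nM to 1000000 nM as its estimated range.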

Compound 4, solubility: 230000 nM
Estimate against measurement, compound 4: 2.8-fold (0.45 log units) above; measured number outside the range, below it.
By their numbers in this assay, from the lowest: compounds 4, 3, 1 and 2 (each within the scatter of the next, the first and the last beyond it).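

In this assay the swap on the carbonyl carbon gives a 1.9-fold lower number from compound 3 to compound 4 (0.28 log units; within the scatter) and so stays unresolved, while the pyridine substituent now matters: 5-aminopyridin-3-yl in place of 6-aminopyridin-3-yl gives a 3.3-fold lower number from compound 2 to compound 4 (0.52 log units; beyond the scatter) and amino in place of hydrogen gives a 3.0-fold lower number from compound 1 to compound 4 (0.48 log units; beyond the scatter) in this placement. So an amino group can leave the number unresolved in one placement, as with a 1.1-fold higher number from compound 1 to compound 2 (0.04 log units; within the scatter) and yet shift it modestly in another. No measurement here accounts for this difference.

Open, on these data alone, is how a longer chain or a carboxylic acid on the carbonyl carbon would read. Also open, as far as these compounds go, is whether amino placement counts the same with oxan-4-yl there.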